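Swapping the aniline halogen pattern on a thienopyrimidine amide

The compounds below may be only part of what the source reports. "The series", "measured", "known", "first", "only" and "open" are said of these compounds alone.

The study concerns two measured compounds and one whose value is still awaited. Compound 1, `O=C(/C=C/c1ccc(O)cc1)Nc1cc2c(Nc3ccc(Cl)c(Cl)c3)ncnc2s1`, and compound 2, `O=C(/C=C/c1ccccc1)Nc1cc2c(Nc3cccc(Cl)c3F)ncnc2s1`, share the same core and were both tested in a functional assay on MDA-MB-231 cells (Homo sapiens) for antiproliferative activity, read by MTT assay, with a stated time of 48 h; a higher number here means a weaker inhibitor, a lower number a stronger inhibitor. Compound 1 gives 1980 nM in this assay, and compound 2 gives 3930 nM. The two numbers lie within the usual scatter of repeated measurements, so compound 2 cannot be called weaker or stronger than compound 1 on this evidence; it simply carries the larger of the two values.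

Compound 3, `O=C(/C=C/c1ccccc1)Nc1cc2c(Nc3ccc(Cl)c(Cl)c3)ncnc2s1`, derives from compound 2 by a single change, (3,4-dichlorophenyl in place of 3-chloro-2-fluorophenyl on a nitrogen on an aromatic ring). For the measured compounds named here, no measured pair in the set isolates this particular exchange, so its effect is unknown from the data. Given that both measured compounds sit in the low-micromolar range and within scatter of each other, compound 3 is expected to land near them, with a step of a 1.5-fold lower number from compound 2 to compound 3 (0.18 log units; within the scatter) that is not expected to exceed the scatter. Compound 3 is therefore estimated at 2600 nM, within a range of 1000 nM to 6500 nM.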

Compound 3, half-maximal inhibitory concentration: 4400 nM
The estimate for compound 3 lay 1.7-fold (0.23 log units) below the measured number; the measured number falls inside the stated range.
By their numbers in this assay, from the lowest: compounds 1, 2 and 3 (each within the scatter of the next, the first and the last beyond it).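

In this assay, for the compounds shown here, 3,4-dichlorophenyl in place of 3-chloro-2-fluorophenyl on a nitrogen on an aromatic ring gives a 1.1-fold higher number from compound 2 to compound 3 (0.05 log units; within the scatter) and is the first reading of this exchange on its own, so at this position the two halogen patterns cannot be told apart in this assay. With 3,4-dichlorophenyl held the same, hydrogen in place of hydroxy on an aromatic carbon gives a 2.2-fold higher number from compound 1 to compound 3 (0.35 log units; beyond the scatter) and is a modest step, which makes this the only single change shown that exceeds the scatter and places the clearer difference at the hydroxy position rather than on the nitrogen substituent. Nothing available accounts for either result.

The compounds shown leave open whether the hydroxy step would hold with 3-chloro-2-fluorophenyl on the nitrogen, and whether a methoxy group or an amine on that aromatic carbon would read like hydroxy or like hydrogen. They also leave open whether a 3,4-difluorophenyl or an unsubstituted phenyl on the nitrogen would stay within the scatter of these two halogen patterns.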